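The compounds below may be only part of what the source reports. "The series", "measured", "known", "first", "only" and "open" are said of these compounds alone.

In a functional assay on HCT-116 cells (Homo sapiens) for inhibition, read by CCK-8 assay, with a stated time of 48 h (on this read-out higher numbers stand for weaker inhibition and lower numbers for stronger inhibition), three compounds that share one core have been measured so far. Compound 1 `COc1cc(-c2ccnc3cc(-c4ccc(F)cc4)nn23)cc(OC)c1OC` gives 5030 nM, compound 2 `COc1cc(-c2ccnc3cc(-c4cn(C)c5ccccc45)nn23)cc(OC)c1OC` gives 762 nM, and compound 3 `COc1cc(-c2ccnc3cc(-c4ccc(C(C)=O)cc4)nn23)cc(OC)c1OC` gives 4390 nM. Compound 3 therefore stands level with compound 1, within the usual scatter, and both sit above compound 2, the strongest inhibitor of the three.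

The next compound is compound 4 `COc1cc(-c2ccnc3cc(-c4ccc(C(C)(C)C)cc4)nn23)cc(OC)c1OC`. It differs from compound 3 by tert-butyl in place of acetyl on an aromatic carbon, para to a large group.

For the measured compounds named here, the closest precedent is a swap of acetyl in place of fluoro on an aromatic carbon, a 1.1-fold lower number from compound 1 to compound 3 (0.06 log units; within the scatter), which stayed within the scatter. Larger changes appear only where 1-methyl-1H-indol-3-yl enters or leaves: a 6.6-fold lower number from compound 1 to compound 2 (0.82 log units; beyond the scatter), and a 5.8-fold higher number from compound 2 to compound 3 (0.76 log units; beyond the scatter). Compound 4 has no 1-methyl-1H-indol-3-yl and keeps a substituted phenyl, so no step beyond the scatter is expected in this assay. This rests on a single comparable swap, so the range stays wide.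

The expected step is a 1.1-fold lower number from compound 3 to compound 4 (0.04 log units; within the scatter). For compound 4 the estimated value is 4000 nM, with an expected range from 1800 nM to 9000 nM.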

Compound 4, half-maximal inhibitory concentration: > 10000 nM
Compound 4 ended at the assay's limit; the forecaster's own chance of this, stated with the estimate: 5%; middle value at least 2.5-fold (0.39 log units) away from the limit.
By their numbers in this assay, from the lowest: compound 2; then compounds 3 and 1 (each within the scatter of the next). At a limit, above all of these: compound 4.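

In this assay compound 4 is recorded only as a limit of the assay, not as a number: the limit of > 10000 nM in this assay, at which 1 of the 4 values shown sits.

Even so, this spot on the phenyl ring, para to a large group, proves sensitive to what it carries: an at least 2.2-fold higher number from compound 3 to compound 4 (0.35 log units; beyond the scatter) lies beyond the scatter, whereas the earlier swap of fluoro for acetyl, a 1.1-fold lower number from compound 1 to compound 3 (0.06 log units; within the scatter), lay within it, so the earlier compounds gave no sign that a simple group here could matter. The 4-(tert-butyl)phenyl group also falls well short of the 1-methyl-1H-indol-3-yl group, an at least 13-fold higher number from compound 2 to compound 4 (1.11 log units; beyond the scatter), while the floor of an at least 1.9-fold higher number from compound 1 to compound 4 (0.29 log units; that floor lies within the scatter) lies within the scatter, so that step alone does not separate the two compounds.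

Going by these compounds, how far the true number for compound 4 lies past the limit remains unknown, which means the real size of these steps is also unknown. On these data alone, it is also open how an amine, a carboxylic acid or a longer chain in place of tert-butyl on this same carbon would read in this assay, and so whether tert-butyl is a lone case or part of a wider trend.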